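Chloro Placement on the Phenyl Ring and Receptor Binding

A few compounds are considered here, and "the series" means these few. Any claim that something is new, unique, unknown or untested is made for them only; others in the source may bear on it.

Of the compounds shown here, three have been measured in an assay on isolated protein for binding affinity to 5-hydroxytryptamine receptor 6 (Homo sapiens); a lower number here means a stronger inhibitor, a higher number a weaker inhibitor. Compound 1 `Clc1ccc(-c2n[nH]cc2N2CCCNCC2)cc1` gives 1090 nM, compound 2 `c1ccc(-c2n[nH]cc2N2CCCNCC2)cc1` gives 3480 nM, and compound 3 `c1ccc(-c2n[nH]cc2N2CCNCC2)cc1` gives 185 nM, the strongest of the three. The cores of compound 3 and compound 2 differ; that difference is not broken down here.

Compound 1 arises from compound 2 by one change, (chloro in place of hydrogen on an aromatic carbon), which produced a 3.2-fold lower number from compound 2 to compound 1 (0.50 log units; beyond the scatter). Compound 4 `Clc1ccccc1-c1n[nH]cc1N1CCNCC1`, not yet measured, arises from compound 3 by the same kind of change, (chloro in place of hydrogen on an aromatic carbon). The two changes are alike in what leaves and what enters, but the place differs: in compound 1 the chloro sits para to a large group, in compound 4 ortho to a large group.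

Set beside the earlier step, the step from compound 3 to compound 4 is expected to be smaller, at a 1.5-fold lower number from compound 3 to compound 4 (0.19 log units; within the scatter), since the only measured guide is compound 1 with its a 3.2-fold lower number from compound 2 to compound 1 (0.50 log units; beyond the scatter), made at a different place on the ring. Compound 4 is therefore estimated at 120 nM, with a range from 40 nM to 400 nM.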

Compound 4, inhibition constant: > 10000 nM
Compound 4: only a limit was reported; the forecaster's own chance of this, stated with the estimate: 2%; at least 83-fold (1.92 log units) between middle value and limit.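

Compound 4 gives > 10000 nM in this assay, which is a limit of the assay and not a number. Even so, the direction is clear: chloro in place of hydrogen on an aromatic carbon gave an at least 54-fold higher number from compound 3 to compound 4 (1.73 log units; beyond the scatter), against a 3.2-fold lower number from compound 2 to compound 1 (0.50 log units; beyond the scatter), so the gain seen on one core did not carry over to the other: the same change on two cores in this assay, a 3.2-fold lower number (0.50 log units; beyond the scatter) from compound 2 to compound 1 and an at least 54-fold higher number (1.73 log units; beyond the scatter) from compound 3 to compound 4, at least 170-fold (2.23 log units) apart, beyond the scatter of two such steps This does not show that the core alone decides the outcome, since the chloro in compound 4 is ortho to a large group while in compound 1 it sits elsewhere on the ring, and the two compounds thus differ in core and place together.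

Still open, on these data alone, is how chloro behaves on each core at the place it holds on the other, which would separate the two factors. Also open, as far as these compounds go, is whether a fluoro, methyl or methoxy group ortho to a large group on the core of compound 3 would give the same result as chloro.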